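Benzyl replacement on the compound 1 core: tert-butylphenyl for chlorophenyl

The compounds below may be only part of what the source reports. "The series", "measured", "known", "first", "only" and "open" are said of these compounds alone.

Of the compounds shown here, three have numbers so far. In a functional assay on L1210 cells (Mus musculus) for cytotoxicity, read by cell counting, with a stated time of 2 days (on this read-out higher numbers stand for weaker inhibition and lower numbers for stronger inhibition), compound 1 `C=C(Br)C(=O)Nc1ccc(/C=C2\SC(=O)N(Cc3cccc(Cl)c3)C2=O)cc1` gives 3400 nM and stands lowest of the three numbers, though each of its steps to the others lies within the scatter. Among the compounds with values here, compound 2 `Nc1ccc(/C=C2\SC(=O)N(Cc3cccc(Cl)c3)C2=O)cc1` gives 4700 nM in this assay, and the step of a 1.4-fold higher number from compound 1 to compound 2 (0.14 log units; within the scatter) is the only one between compounds that differ in one place. Within the data shown here, compound 3 `Nc1ccc(/C=C2\SC(=O)N(Cc3ccc(C(F)(F)F)cc3)C2=O)cc1` gives 6000 nM in this assay; compound 2 and compound 3 differ at the benzyl position, but no step is given for that pair, so only their two values are known.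

Compound 4 `C=C(Br)C(=O)Nc1ccc(/C=C2\SC(=O)N(Cc3ccc(C(C)(C)C)cc3)C2=O)cc1` differs from compound 1 by 4-(tert-butyl)phenyl in place of 3-chlorophenyl on a saturated chain carbon bound to an amide-type nitrogen in a ring. Among the measured compounds shown here, no measured step touches this exact change. For the measured compounds named here, the only pair that varies the same place, compound 2 and compound 3, shows two numbers close to each other, so no movement beyond the scatter is expected. For compound 4 the estimate in this assay is 4500 nM, with a range from 2000 nM to 10000 nM, which amounts to an expected step of a 1.3-fold higher number from compound 1 to compound 4 (0.12 log units; within the scatter).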

Compound 4, half-maximal inhibitory concentration: 1600 nM
Compound 4: middle estimate off by 2.8-fold (0.45 log units), on the high side; the whole stated range lies above it.
By their numbers in this assay, from the lowest: compound 4; then compounds 1, 2 and 3 (each within the scatter of the next).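

In this assay, within the data shown here, the change at this position gives a 2.1-fold lower number from compound 1 to compound 4 (0.33 log units; beyond the scatter), the first step that lies beyond the scatter, and it shows that this place on a saturated chain carbon bound to an amide-type nitrogen in a ring can move the number when the (1-bromoethenyl)carbonyl group is present. The substituent and its location on the phenyl ring change together here, so the step cannot be assigned to either alone. Nothing available gives a reason for the step.

Going by these compounds, it remains open whether the tert-butyl group or its location on the ring carries the step, and whether the same change does anything on the core of compound 2. Also open, on these data alone, is how a carboxylic acid on that phenyl ring, or a longer chain in place of the benzyl link, would read.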